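Swapping the triazole substituent back to an anilide arm

This account rests on a few compounds, and the source may have more. Where it says the series, first, only, none or still open, it means among the compounds named here.

In a functional assay on A549 cells (Homo sapiens) for inhibition, read by MTT assay, with a stated time of 24 h (a lower number here means a stronger inhibitor, a higher number a weaker inhibitor), two compounds sharing one core have been measured so far. Compound 1 `CCOC(=O)C1=Cc2ccccc2OC1(OCc1cn(CC(=O)Nc2ccccc2F)nn1)C(F)(F)F` gives 50100 nM in this assay. For the measured compounds named here, compound 2 `CCOC(=O)C1=Cc2ccccc2OC1(OCc1cn(-c2ccc(F)c(Cl)c2)nn1)C(F)(F)F` gives 26300 nM in this assay, the lowest of the two numbers, with compound 1 as its only neighbour; the single step between them, a 1.9-fold lower number from compound 1 to compound 2 (0.28 log units; within the scatter), does not rise above the scatter of the method.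

Compound 3 `CCOC(=O)C1=Cc2ccccc2OC1(OCc1cn(CC(=O)Nc2cccc(F)c2)nn1)C(F)(F)F` has not yet been measured in this assay. Its difference from compound 2 is ((3-fluorophenyl)carbamoyl)methyl in place of 3-chloro-4-fluorophenyl on an aromatic nitrogen. Going by the values given here, this change runs in the opposite sense to the one measured step, which traded an anilide arm on the same aromatic nitrogen for the halogenated phenyl ring and moved the number only within the scatter. Among the compounds with values here, the anilide arm entering here carries its fluorine at the 3-position rather than the 2-position, so the comparison is not exact, but it is the only guide.

Compound 3 is therefore expected to sit near compound 1, with an estimated 45000 nM (range 18000 nM to 110000 nM). That estimate means a step of a 1.7-fold higher number from compound 2 to compound 3 (0.23 log units; within the scatter), expected to stay within the scatter.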

Compound 3, half-maximal inhibitory concentration: > 150000 nM
Compound 3: no number, only a limit (the forecaster's own chance of this, stated with the estimate: 10%); middle value at least 3.3-fold (0.52 log units) away from the limit.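

For compound 3, the reading in this assay is a limit of the assay and not a number: the limit of > 150000 nM in this assay, at which 1 of the 3 values shown sits.

Even so, it shows that exchanging groups on this aromatic nitrogen is not neutral: the new step, an at least 5.7-fold higher number from compound 2 to compound 3 (0.75 log units; beyond the scatter), lies beyond the scatter, whereas the earlier exchange of an anilide arm for the 3-chloro-4-fluorophenyl ring, a 1.9-fold lower number from compound 1 to compound 2 (0.28 log units; within the scatter), stayed within it. It also shows that the anilide arm cannot be treated as a single group at this position, since 3-fluorophenyl in place of 2-fluorophenyl on the amide-type nitrogen gives an at least 2.9-fold higher number from compound 1 to compound 3 (0.47 log units; beyond the scatter), so in this pair the placing of one fluorine on the arm's ring alone moves the result beyond the scatter.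

On these data alone, the true size of both new steps stays open, since each rests on a limit rather than on a number. Also open, as far as these compounds go, is whether an unsubstituted phenyl or a chlorophenyl on the amide-type nitrogen, or a longer chain in the arm, would return a number in this assay.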